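This account rests on a few compounds, and the source may have more. Where it says the series, first, only, none or still open, it means among the compounds named here.

Compounds measured so far:
- compound 1 `COc1cc(C)nc2n/c(=N/C(=O)c3c(-c4ccc(Cl)cc4Cl)noc3C)sn12`: 45.7%
- compound 2 `CSc1cc(C)nc2n/c(=N/C(=O)c3c(-c4ccc(Cl)cc4Cl)noc3C)sn12`: 21.9%

In a functional assay on the whole organism for inhibition, with Chenopodium ficifolium as the target, with a stated time of 72 h, tested at 10 mg/L (on this read-out lower numbers stand for less inhibition of growth and higher numbers for more inhibition of growth at the one concentration tested), compound 1 gives 45.7%, the highest of the two numbers measured; the nearest is compound 2, and the step from one to the other is a number 23.8 percentage points lower from compound 1 to compound 2 (beyond the scatter), a change beyond the usual scatter.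

Compound 3 `COc1cc(SC)nc2n/c(=N/C(=O)c3c(-c4ccc(Cl)cc4Cl)noc3C)sn12` is the unmeasured compound. It differs from compound 1 in one place: methylsulfanyl in place of methyl on an aromatic carbon. The methylsulfanyl group enters at a position on the shared core that is next to the ring nitrogen and meta to a methoxy group, so the methoxy of compound 1 stays in place.

For the measured compounds named here, only one measured step bears on this change. It also brings in a methylsulfanyl group, although there it replaced a methoxy, and it lowered inhibition by a number 23.8 percentage points lower from compound 1 to compound 2 (beyond the scatter). On that basis a decrease beyond the scatter is expected for compound 3 as well, though a smaller one, since the change sits at a different position and the methoxy is kept. The expected step is a number 13.7 percentage points lower from compound 1 to compound 3 (beyond the scatter), giving an estimate for compound 3 of 32%, with a range from 14% to 50%.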

Compound 3, percent growth inhibition at one concentration: 23.8%
Compound 3: the middle estimate sits 8.2 percentage points above what was measured; the range from low to high includes it.
By their numbers in this assay, from the lowest: compounds 2 and 3 (each within the scatter of the next); then compound 1.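

In this assay, methylsulfanyl in place of methyl on the aromatic carbon next to the ring nitrogen gives a number 21.9 percentage points lower from compound 1 to compound 3 (beyond the scatter) even though the methoxy group stays in place. For the compounds shown here, the only earlier methylsulfanyl change, a number 23.8 percentage points lower from compound 1 to compound 2 (beyond the scatter), replaced that methoxy group, so it could not show whether losing the methoxy was needed for a drop; the new step shows that inhibition also falls when the methoxy group is kept and the methyl is the group that leaves. No measurement shown here gives a reason for the fall in inhibition at this position.

From the compounds shown here alone, with only methyl and methylsulfanyl seen at this position, it remains open whether the fall belongs to methylsulfanyl in particular or would also appear with other groups there, such as an amine, a chlorine atom or a longer chain like ethyl. Going by these compounds, all of these readings also come from one plant species at one concentration, so how the compounds would compare at other concentrations or in other species remains unknown.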